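The compounds below may be only part of what the source reports. "The series", "measured", "known", "first", "only" and "open" are said of these compounds alone.

Of the compounds shown here, three built on one shared core have been measured in a functional assay on PC-3 cells (Homo sapiens) for inhibition, read by MTT assay, with a stated time of 72 h; a higher number here means a weaker inhibitor, a lower number a stronger inhibitor. Compound 1 `C=CC(=O)Nc1cccc(NC(=O)CSc2nc(Nc3cccc(F)c3)c3ccccc3n2)c1` gives 5370 nM in this assay. Compound 2 `C=CC(=O)Nc1cccc(NC(=O)CSc2nc(Nc3cccc(Cl)c3)c3ccccc3n2)c1` gives 12300 nM in this assay, and the step of a 2.3-fold higher number from compound 1 to compound 2 (0.36 log units; beyond the scatter) goes with the change (chloro in place of fluoro on an aromatic carbon). Compound 3 `C=CC(=O)Nc1cccc(NC(=O)CSc2nc(Nc3ccc(F)cc3)c3ccccc3n2)c1` gives 8240 nM in this assay; its core differs from that of compound 1 by 4-fluorophenyl in place of 3-fluorophenyl on a nitrogen on an aromatic ring, and the step of a 1.5-fold higher number from compound 1 to compound 3 (0.19 log units; within the scatter) lies within the scatter, as does the step of a 1.5-fold lower number from compound 2 to compound 3 (0.17 log units; within the scatter).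

Compound 4 `C=CC(=O)Nc1cccc(NC(=O)CSc2nc(Nc3ccc(Cl)cc3)c3ccccc3n2)c1` has not yet been measured. It differs from compound 3 by chloro in place of fluoro on an aromatic carbon. This is the same kind of change as that from compound 1 to compound 2, not the same change, for in compound 4 the chloro sits para to a large group, whereas in compound 2 it sits meta to a large group. Among the measured compounds shown here, the expectation for compound 4 is a step of a 1.8-fold higher number from compound 3 to compound 4 (0.26 log units; within the scatter), and that expectation rests on the step of a 2.3-fold higher number from compound 1 to compound 2 (0.36 log units; beyond the scatter) as the only guide to this kind of change. The estimate for compound 4 in this assay is therefore 15000 nM, with a range from 7000 nM to 35000 nM.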

Compound 4, half-maximal inhibitory concentration: 10800 nM
For compound 4 the middle estimate is 1.4-fold (0.14 log units) above the measured one; measured number inside the range.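

In this assay, chloro in place of fluoro on the 4-fluorophenyl group gives a 1.3-fold higher number from compound 3 to compound 4 (0.12 log units; within the scatter), and the two cores that carry this change can be compared directly: the same change on two cores in this assay, a 2.3-fold higher number (0.36 log units; beyond the scatter) from compound 1 to compound 2 and a 1.3-fold higher number (0.12 log units; within the scatter) from compound 3 to compound 4, 1.7-fold (0.24 log units) apart, within the scatter of two such steps. This shows that the change carries from the core of compound 1 to the core of compound 3 without a difference that can be told from the scatter, but it does not fix a single size for the step, and two cores are too few to speak for the series. The replacements of the whole aryl group, a 1.1-fold lower number from compound 2 to compound 4 (0.06 log units; within the scatter) and a 2.0-fold higher number from compound 1 to compound 4 (0.30 log units; within the scatter), also lie within the scatter, so these compounds give no clear preference between the substituted phenyl groups.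

As far as these compounds go, it remains open whether the same step would hold for bromo, methyl, methoxy or trifluoromethyl on this phenyl ring. From the compounds shown here alone, it also remains open whether it would survive replacing the acrylamide with a saturated propanamide.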